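Exchanging one carbonyl substituent at the tolerance limit

The source may hold more compounds than are shown below. What is called first, only, known or untested is meant among the compounds shown, and "the series" means these compounds.

- compound 1 `COc1ccc(-c2cnc(NC(=O)c3ncc[nH]3)n2C)cc1` – > 100000 nM
- compound 2 `CCC(=O)Nc1ncc(-c2ccc(OC)cc2)n1C` – > 100000 nM
- compound 3 `COc1ccc(-c2cnc(NC(=O)c3ccc(O)cc3)n2C)cc1` – > 100000 nM

All three entries are limits of the assay and not numbers, as the evidence shows (the limit of > 100000 nM in this assay, at which 3 of the 3 values shown sit). In a toxicity assay on THP-1 cells (Homo sapiens) for inhibition (a lower number here means that less compound is tolerated, a higher number that more compound is tolerated), compound 3 gives > 100000 nM, which is a limit like the two others.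

Compound 4 `COc1ccc(-c2cnc(NC(=O)c3cnco3)n2C)cc1` carries 1,3-oxazol-5-yl in place of 4-hydroxyphenyl on a carbonyl carbon. Three measured changes at that same carbonyl carbon bear on this: (a step that the two limits leave unreadable from compound 1 to compound 3), (a step that the two limits leave unreadable from compound 2 to compound 3) and (a step that the two limits leave unreadable from compound 1 to compound 2). None of them has a readable size, so they give neither a magnitude nor a direction. Each of the three groups tried at this place left the read-out at the limit, and compound 4 is expected to behave the same way. The expected change is therefore none beyond the scatter (a number no higher from compound 3 to compound 4 (the limit leaves the size open)). Compound 4 is estimated at 100000 nM, with an expected range from 40000 nM to 200000 nM, and most likely it too will be reported only as a limit.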

Compound 4, half-maximal cytotoxic concentration: > 100000 nM
Compound 4 was reported as a limit; the forecaster's own chance of this, stated with the estimate: 85%; the middle value sits exactly at the limit.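

In this assay compound 4 gives > 100000 nM as a limit and not as a number. Going by these compounds alone, no step among compound 1, compound 2, compound 3 and compound 4 can be read: the limit of > 100000 nM in this assay, at which 4 of the 4 values shown sit. The compounds shown leave open where any of the four would give an actual value and whether the carbonyl substituent alters it.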